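The compounds below may be only part of what the source reports. "The series", "measured", "known", "first", "only" and "open" are said of these compounds alone.

Compound 2 (`COc1ccc(Cn2c(C)cc(OCc3cccc(F)c3)cc2=O)cc1`) gives < 6400 nM in an ADME assay on Vero cells (Chlorocebus sabaeus) for cytotoxicity (on this read-out lower numbers stand for higher toxicity in this test and higher numbers for lower toxicity in this test), as a limit and not as a number. It stands at the limit of < 6400 nM in this assay, at which 2 of the 3 values shown sit, and has no measured number of its own. Compound 3 (`Cc1cc(OCc2cccc(F)c2)cc(=O)n1Cc1ccc(Cl)cc1`) gives < 6400 nM in this assay and this too is a limit. Compound 1 (`Cc1cc(OCc2ccc(F)cc2F)cc(=O)n1Cc1ccc(C(F)(F)F)cc1`) carries 2,4-difluorophenyl and gives < 4800 nM in this assay as a limit as well.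

The change to compound 4 (`COc1ccc(Cn2c(C)cc(OCc3ccc(F)cc3F)cc2=O)cc1`) puts 2,4-difluorophenyl in place of 3-fluorophenyl on a saturated chain carbon bound to an oxygen on an aromatic ring. Among the compounds with values here, the one measured step in a single place (a step that the two limits leave unreadable from compound 2 to compound 3) puts chloro in place of methoxy on an aromatic carbon. That is a different change at a different place, and it supplies no size to carry over. With no readable step to lean on, the expectation in this assay is a step that the limit leaves unreadable from compound 2 to compound 4 and none beyond the scatter, with no direction that the data can support. For compound 4 the estimate is 5500 nM with an expected range from 2500 nM to 6500 nM and the reading is expected most likely to come back as a limit again.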

Compound 4, half-maximal cytotoxic concentration: < 4600 nM
Compound 4 ended at the assay's limit (the forecaster's own chance of this, stated with the estimate: 80%); middle value at least 1.1-fold (0.07 log units) away from the limit.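

In this assay compound 4 gives < 4600 nM, which is a limit. The steps to compound 4 from compound 1 and from compound 2 cannot be read, as all three values are limits. The compounds shown leave open the size and direction of either change in this assay, as none of the four values is a measured number.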